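The source may report more compounds than this note shows. Statements on the series, on what has been measured and on what is new or still open speak of the compounds shown alone.

In a functional assay on MCF7 cells (Homo sapiens) for antiproliferative activity, read by MTT assay (on this read-out higher numbers stand for weaker inhibition and lower numbers for stronger inhibition), the measured values are:
- compound 1 (`COc1cc2c(Oc3ccc(NC(=O)Nc4ccc(Cl)c(C(F)(F)F)c4)cc3)ccnc2cc1OCCCCCCC(=O)NO`): 5150 nM
- compound 2 (`COc1cc2c(Oc3ccc(NC(=O)Nc4ccc(C)cc4C)cc3)ccnc2cc1OCCCCCCC(=O)NO`): 3430 nM
- compound 3 (`COc1ccccc1NC(=O)Nc1ccc(Oc2ccnc3cc(OCCCCCCC(=O)NO)c(OC)cc23)cc1`): 6280 nM

Compound 2 cannot be separated from the other two compounds: both of its steps (a 1.5-fold lower number from compound 1 to compound 2 (0.18 log units; within the scatter)) and (a 1.8-fold higher number from compound 2 to compound 3 (0.26 log units; within the scatter)) lie within the scatter, as does the remaining step (a 1.2-fold higher number from compound 1 to compound 3 (0.09 log units; within the scatter)).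

Compound 4 (`COc1cc2c(Oc3ccc(NC(=O)NNC(=O)c4cccc(C)c4)cc3)ccnc2cc1OCCCCCCC(=O)NO`) differs from compound 2 as follows (((3-methylphenyl)carbonyl)amino in place of 2,4-dimethylphenyl on an amide-type nitrogen): ((3-methylphenyl)carbonyl)amino in place of 2,4-dimethylphenyl on an amide-type nitrogen. Cut one bond further out, this reads (2,4-dimethylphenyl)amino to (((3-methylphenyl)carbonyl)amino)amino.

The three measured steps all exchange one substituted phenyl group for another on that nitrogen. None adds the carbonyl and amino unit, so they bear on this change only in part, and the range is kept wide. In this assay the expected step (a 1.3-fold higher number from compound 2 to compound 4 (0.12 log units; within the scatter)) is estimated to stay within the scatter, with no firm direction. The estimate for compound 4 is 4500 nM as the middle value, with an expected range from 1500 nM to 13000 nM in repeat measurements.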

Compound 4, half-maximal inhibitory concentration: 5830 nM
Estimate against measurement, compound 4: 1.3-fold (0.11 log units) below; low and high end bracket the measured number.
By their numbers in this assay, from the lowest: compounds 2, 1, 4 and 3 (each within the scatter of the next).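

In this assay, among the compounds shown here, ((3-methylphenyl)carbonyl)amino is the first group on this amide-type nitrogen that places a carbonyl and amino unit before the aromatic ring, yet compound 4 cannot be separated from any earlier compound (a 1.7-fold higher number from compound 2 to compound 4 (0.23 log units; within the scatter); a 1.1-fold lower number from compound 3 to compound 4 (0.03 log units; within the scatter); a 1.1-fold higher number from compound 1 to compound 4 (0.05 log units; within the scatter)). Among these four compounds, neither the exchange of one substituted phenyl group for another nor this added unit gives a step beyond the scatter. No available evidence explains this lack of separation.

Going by these compounds, it remains open whether a group without an aromatic ring on this nitrogen, such as cyclohexyl or a short chain ending in a carboxylic acid, would give a step beyond the scatter. A morpholine or piperazine ring at this position is equally unresolved.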